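The source may hold more compounds than are shown below. What is called first, only, known or untested is meant among the compounds shown, and "the series" means these compounds.

Measured in a functional assay on A-431 cells (Homo sapiens) for antiproliferative activity, read by sulforhodamine B assay, with a stated time of 72 h; a lower number here means a stronger inhibitor, a higher number a weaker inhibitor:
- compound 1 `C=C1CC(CBr)(c2ccc(OC)cc2)OC1=O`: 4200 nM
- compound 2 `C=C1C[C@](CCl)(c2ccccc2)OC1=O`: 30600 nM
- compound 3 `C=C1CC(CF)(c2ccccc2)OC1=O`: 25100 nM

Lower numbers mean stronger inhibition of cell growth, so the placing of compound 3 matters. In this assay compound 3 gives 25100 nM, which lies within the usual scatter of compound 2 at 30600 nM. Compound 1 gives a lower number, 4200 nM, and that gap from compound 3 is beyond the scatter.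

The next compound to consider is compound 4 `C=C1CC(C[Se]c2ccccc2)(c2ccccc2)OC1=O`. It keeps the shared core of compound 3 and changes one group: a group of 7 heavy atoms (6 carbon, 1 selenium; one six-membered aromatic ring of carbon only) in place of one fluorine atom, on a saturated chain carbon bound to a saturated ring carbon. The incoming group holds a selenium atom and a six-membered aromatic ring of carbon only, and it sits on a saturated chain carbon bound to a saturated ring carbon.

Among the measured compounds shown here, no measured pair differs in just one place, so the data give no direct guide to the size of this step. Compound 1, at 4200 nM, shows that this family can reach lower numbers, but it differs from compound 3 in more than one place. A moderate move towards a lower number therefore seems a reasonable expectation, though the uncertainty is wide.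

The estimate implies an expected 3.1-fold lower number from compound 3 to compound 4 (0.50 log units; beyond the scatter). For compound 4 the expected value is 8000 nM, with an estimated range of 2000 nM to 30000 nM.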

Compound 4, half-maximal inhibitory concentration: 1270 nM
Beside the measured number, compound 4's estimate is 6.3-fold (0.80 log units) above it, outside the stated range (below it).
By their numbers in this assay, from the lowest: compound 4; then compound 1; then compounds 3 and 2 (each within the scatter of the next).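

In this assay, the saturated chain carbon bound to a saturated ring carbon turns out to be a place where a single change can shift the number a long way: replacing one fluorine atom with a group of 7 heavy atoms that holds selenium and a six-membered aromatic ring of carbon only gives a 20-fold lower number from compound 3 to compound 4 (1.30 log units; beyond the scatter) and counts as a large step. Among the compounds shown here, the earlier compounds offered no pair differing in one place, so this is the first direct reading of what a change at this position can do, and it shows that a far bulkier group than fluorine is compatible with stronger inhibition of cell growth. Nothing available explains why the number falls, so the step stands as an observation without a known cause.

The selenium atom and the aromatic ring enter together, so this one step cannot say which of them, if either, accounts for the drop. A version with sulfur in place of selenium, a benzyl group without selenium, or an amine on the same chain carbon would help to separate these parts, and the compounds shown give no reading for any of them.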